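Replacing a cyclopropyl amide with a bulky nitroxide ring

This account rests on a few compounds, and the source may have more. Where it says the series, first, only, none or still open, it means among the compounds named here.

Compound 3, `Cn1cc(-c2nn(Cc3ccc(C(=O)NC4CC4)cc3)c(=O)c3ccccc23)cn1`, is measured in a functional assay on HepG2 cells (Homo sapiens) for antiproliferative activity, read by MTT assay, with a stated time of 72 h (a higher number here means a weaker inhibitor, a lower number a stronger inhibitor), where it gives only a limit, > 100000 nM, and no number. Compound 2, `Cc1noc(C)c1-c1nn(Cc2ccc(C(=O)NC3CC3)cc2)c(=O)c2ccccc12`, likewise gives only a limit in this assay, > 100000 nM. Compound 1, `Cc1noc(C)c1-c1nn(Cc2ccc(C(=O)NC3CCCCC3)cc2)c(=O)c2ccccc12`, also reaches only the limit, > 100000 nM. Because of the limit of > 100000 nM in this assay, at which 3 of the 3 values shown sit, neither step is readable: the change from compound 1 to compound 2 at the amide nitrogen gives a step that the two limits leave unreadable from compound 1 to compound 2, and the change on the aromatic carbon gives a step that the two limits leave unreadable from compound 2 to compound 3.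

Compound 4, `Cn1cc(-c2nn(Cc3ccc(C(=O)NC4CC(C)(C)N([O])C(C)(C)C4)cc3)c(=O)c3ccccc23)cn1`, differs from compound 3 by a group of 11 heavy atoms (9 carbon, 1 nitrogen, 1 oxygen; one six-membered non-aromatic ring with 1 hetero atom) in place of a group of 3 heavy atoms (3 carbon; one three-membered non-aromatic ring of carbon only), on an amide-type nitrogen. Within the data shown here, the only measured change at the same amide nitrogen, from compound 1 to compound 2, offers no readable size, so the data give no direction for this new group. With all three measured compounds sitting at the limit, compound 4 is expected to show a number no higher from compound 3 to compound 4 (the limit leaves the size open), most likely again a limit. The value estimated for compound 4 in this assay is 100000 nM, within a range from 20000 nM to 300000 nM.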

Compound 4, half-maximal inhibitory concentration: 27400 nM
For compound 4 the middle estimate is 3.6-fold (0.56 log units) above the measured one; the range from low to high includes it.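

In this assay, the group of 11 heavy atoms on the amide-type nitrogen, in place of cyclopropyl, gives an at least 3.6-fold lower number from compound 3 to compound 4 (0.56 log units; beyond the scatter), the only readable step among the compounds shown. Compound 3 gives only a limit, > 100000 nM, so this step fixes a lower bound on the change and not its full size. The amide nitrogen is thus a place where a change can bring the read-out off the limit, which the two earlier steps could not show, and those steps stay unreadable because of the assay's ceiling: the limit of > 100000 nM in this assay, at which 3 of the 4 values shown sit.

Going by these compounds, whether the gain needs the nitroxide oxygen or only the ring stays open, as does what the same ring would give with a plain amine nitrogen in its place. On these data alone, it is also open whether the same group would give a number with 3,5-dimethyl-1,2-oxazol-4-yl on the aromatic carbon.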